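This account rests on a few compounds, and the source may have more. Where it says the series, first, only, none or still open, it means among the compounds named here.

Compound 1 `CCCCn1cnc2c(NCc3ccc(C(=O)Nc4ccccc4N)cc3)nc(Cl)nc21`: 6.8% in a functional assay on HepG2 cells (Homo sapiens) for antiproliferative activity, read by CCK-8 assay, with a stated time of 72 h, tested at 2 uM; on this read-out lower numbers stand for a weaker effect and higher numbers for a stronger effect at the one concentration tested
Compound 2 `CCCCn1cnc2c(Nc3ccccc3)nc(NCOCc3ccc(C(=O)Nc4ccccc4N)cc3)nc21`: 46.6%

Compound 1 has the lower of the two measured numbers, and compound 2 stands higher by an amount beyond the usual scatter. Compound 3 `Nc1ccccc1NC(=O)c1ccc(CNc2nc(Cl)nc3c2ncn3Cc2ccccc2)cc1` has not yet been measured. It differs from compound 1 by phenyl in place of propyl on a saturated chain carbon bound to an aromatic nitrogen. Within the data shown here, no measured pair of compounds shows this particular change, so its effect is unknown from the data at hand. The expected step of a number 5.2 percentage points higher from compound 1 to compound 3 (within the scatter) is small, at most a slight rise, and may well stay within the scatter. Compound 3 is therefore estimated at 12% in this assay, within a range from 0% to 30%.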

Compound 3, a percentage reported as inhibition, at one concentration (the size of the read-out at that concentration, not a potency): 5.01%
The estimate for compound 3 lay 7 percentage points above the measured number; the range from low to high includes it.
By their numbers in this assay, from the lowest: compounds 3 and 1 (each within the scatter of the next); then compound 2.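

In this assay, phenyl in place of propyl on a saturated chain carbon bound to an aromatic nitrogen gives a number 1.8 percentage points lower from compound 1 to compound 3 (within the scatter). Among these compounds, this is the first direct reading at this position: the butyl and benzyl forms of the chain cannot be told apart here, so this exchange leaves the read-out unresolved at the one concentration tested. Nothing available explains this outcome. The compounds shown leave open what an amine, a carboxylic acid or a longer chain would give at this place, and whether the same exchange reads alike when the chlorine is replaced.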